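The compounds below may be only part of what the source reports. "The series", "measured", "known", "first", "only" and "open" are said of these compounds alone.

Within the data shown here, compound 1 `CCCCC1CCC(OC(=O)N[C@@H](CC(C)C)C(=O)N[C@H](C=O)C[C@@H]2CCNC2=O)CC1` is the only compound with a number in a toxicity assay on Huh-7 cells (Homo sapiens) for cytotoxicity (a higher number here means that more compound is tolerated, a lower number that less compound is tolerated), where compound 1 gives 63300 nM. Compound 2 `CC(C)C[C@H](NC(=O)OCC1CCC(F)(F)CC1)C(=O)N[C@H](C=O)C[C@@H]1CCNC1=O` reaches only a limit of the assay, > 100000 nM. Among the measured compounds shown here, the single measured step, an at least 1.5-fold higher number from compound 1 to compound 2 (0.19 log units; that floor lies within the scatter), alters a different part of the molecule and rests on (the limit of > 100000 nM in this assay, at which 1 of the 2 values shown sits). Compound 3 `CCCCC1CCC(OC(=O)N[C@@H](CC(C)C)C(=O)N[C@@H](C[C@@H]2CCNC2=O)C(O)S(=O)(=O)O)CC1` differs from compound 1 at another site: hydroxy(sulfo)methyl in place of formyl on a saturated chain carbon bound to an amide-type nitrogen and a saturated chain carbon. For the measured compounds named here, no measured step touches that site, so the expected step of a 1.3-fold higher number from compound 1 to compound 3 (0.10 log units; within the scatter) is small and may not exceed the scatter. Compound 3 is estimated at 80000 nM, with a range from 30000 nM to 200000 nM.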

Compound 3, half-maximal cytotoxic concentration: 59100 nM
Compound 3: middle estimate off by 1.4-fold (0.13 log units), on the high side, and the stated range covers the measured number.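

Swapping formyl for hydroxy(sulfo)methyl on this saturated chain carbon gives a 1.1-fold lower number from compound 1 to compound 3 (0.03 log units; within the scatter) in this assay. Among these compounds, this is the first measured step at this site, and it shows that, on the core of compound 1, the swap leaves the read-out within the scatter. No measured property of either group bears on this result.

Still open, as far as these compounds go, is whether other groups at this carbon, such as a carboxylic acid or a nitrile, would read alike. Also open, from the compounds shown here alone, is whether the same swap on compound 2 would stay within the scatter.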